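Removing One Fluoro from Compound 3: An Expected Shift

The source may hold more compounds than are shown below. What is called first, only, known or untested is meant among the compounds shown, and "the series" means these compounds.

Compound 1 `CCN(CC)CCCn1c(=O)c(=Cc2ccccc2O)s/c1=C1\C(=O)Nc2ccccc21`: in a functional assay on HT-29 cells (Homo sapiens) for inhibition, read by MTT assay, with a stated time of 72 h (on this read-out higher numbers stand for weaker inhibition and lower numbers for stronger inhibition), compound 1 gives > 200000 nM, which is a limit of the assay and not a number.
Compound 2 `CCN(CC)CCCn1c(=O)c(=Cc2ccc(F)cc2F)s/c1=C1\C(=O)Nc2ccc(Cl)cc21`: in this assay compound 2 gives > 200000 nM, again a limit rather than a number.
Compound 3 `CCN(CC)CCCn1c(=O)c(=Cc2ccc(F)cc2F)s/c1=C1\C(=O)Nc2cc(F)ccc21`: in this assay compound 3 gives 1520 nM.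

Compound 3 is therefore the only one of the three with a measured number; the other two sit at the limit of > 200000 nM in this assay, at which 2 of the 3 values shown sit. Compound 4 `CCN(CC)CCCn1c(=O)c(=Cc2ccc(F)cc2F)s/c1=C1\C(=O)Nc2ccccc21` is the next compound, not yet measured. It differs from compound 3 in one place: hydrogen in place of fluoro on an aromatic carbon. For the measured compounds named here, no step between two measured compounds is available to anchor this change. Compounds 1 and 2, which both lack this fluoro but differ from compound 3 in other places as well, give only limits, so a loss of inhibition on removing the fluoro seems plausible, though its size is uncertain. The expected step from compound 3 to compound 4 is a 2.6-fold higher number from compound 3 to compound 4 (0.42 log units; beyond the scatter), a moderate weakening beyond the usual scatter. Compound 4 is estimated at 4000 nM in this assay, with a range from 1200 nM to 20000 nM.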

Compound 4, half-maximal inhibitory concentration: > 200000 nM
Compound 4 ended at the assay's limit (the forecaster's own chance of this, stated with the estimate: 15%); middle value at least 50-fold (1.69 log units) from the limit.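

In this assay, replacing this one fluoro with hydrogen gives an at least 130-fold higher number from compound 3 to compound 4 (2.11 log units; beyond the scatter), so the fluoro on this aromatic carbon, meta to a fused ring and para to a fused ring, matters a great deal in this series. Compounds 1 and 2 each differ from compound 3 in more than one place, so neither could tie the loss to this fluoro alone, whereas this single change does. Each step from compound 1 or compound 2 to compound 4 joins two limits and cannot be read, and the series now gathers at one value: the limit of > 200000 nM in this assay, at which 3 of the 4 values shown sit.

On these data alone, whether a methyl, a methoxy or a nitrile on this same aromatic carbon would also give a measured number remains open. As far as these compounds go, it is also open whether this fluoro would have the same effect with the 2-hydroxyphenyl of compound 1 in place of the 2,4-difluorophenyl.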